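The compounds below may be only part of what the source reports. "The series", "measured", "known", "first", "only" and "open" are said of these compounds alone.

Measured so far:
compound 1 `CCCS(=O)(=O)Nc1ccc(F)c(C(=O)c2n[nH]c3ncc(-c4ccccc4Cl)cc23)c1F` — 9.3%
compound 2 `CCCS(=O)(=O)Nc1ccc(F)c(C(=O)c2n[nH]c3ncc(-c4ccccc4O)cc23)c1F` — 9%

In an assay for binding affinity to dual specificity mitogen-activated protein kinase kinase 4 (Homo sapiens), read by KINOMEscan, tested at 100 nM (on this read-out lower numbers stand for a stronger effect and higher numbers for a weaker effect at the one concentration tested), compound 1 gives 9.3%, and compound 2 gives 9%. Compound 2 stands with compound 1, the step of a number 0.3 percentage points lower from compound 1 to compound 2 (within the scatter) being within the scatter, so the two are not separated on this read-out.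

The next compound is compound 3 `CCCS(=O)(=O)Nc1ccc(F)c(C(=O)c2n[nH]c3ncc(-c4cccc(N(C)C)c4)cc23)c1F`. The change from compound 2 is 3-(dimethylamino)phenyl in place of 2-hydroxyphenyl on an aromatic carbon.

Going by the values given here, only one measured step exists, and it swaps hydroxy for chloro on an aromatic carbon of the same ring; it says nothing directly about a 3-(dimethylamino)phenyl in place of a 2-hydroxyphenyl. Among the compounds with values here, both measured compounds sit low on this assay, and the one known exchange on that ring left the number unchanged. Compound 3 is therefore expected to stay near compound 2, with an estimated step of a number 3 percentage points higher from compound 2 to compound 3 (within the scatter), likely within the scatter. Compound 3 is estimated at 12%, within 4% to 30%.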

Compound 3, a percentage reported as activity, at one concentration (the size of the read-out at that concentration, not a potency): 26%
For compound 3 the middle estimate is 14 percentage points below the measured one, within the range that was stated.
By their numbers in this assay, from the lowest: compounds 2 and 1 (each within the scatter of the next); then compound 3.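

In this assay this position does respond to its aryl group: 3-(dimethylamino)phenyl in place of 2-hydroxyphenyl gives a number 17 percentage points higher from compound 2 to compound 3 (beyond the scatter), and the same group in place of 2-chlorophenyl gives a number 16.7 percentage points higher from compound 1 to compound 3 (beyond the scatter), both modest, whereas the hydroxy-for-chloro exchange had not separated the earlier pair. The change alters both the substituent and its place on the phenyl ring, and these compounds do not separate the two. Nothing available accounts for the higher number in compound 3.

Still open, from the compounds shown here alone, is how 3-hydroxyphenyl or 2-(dimethylamino)phenyl would read, which would tell the substituent apart from its place on the phenyl ring. Also open, going by these compounds, is how an unsubstituted phenyl, or a phenyl carrying a carboxylic acid or a primary amine, would read at this position.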